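Aryl sulfonyl changes on the shared core: compound 4

The source may report more compounds than this note shows. Statements on the series, on what has been measured and on what is new or still open speak of the compounds shown alone.

Three sulfonamides on the shared core have been measured. Compound 1 `O=S(=O)(NC1=NCCN1C(=S)SN1CCn2c1nsc2=S)c1ccccc1` carries an unsubstituted phenyl on the sulfonyl sulfur. In a functional assay on KYSE-510 cells (Homo sapiens) for antiproliferative activity, read by crystal violet staining, with a stated time of 96 h (a lower number here means a stronger inhibitor of growth, a higher number a weaker inhibitor of growth), compound 1 gives only a limit, >= 20000 nM. Compound 2 `COc1cccc(S(=O)(=O)NC2=NCCN2C(=S)SN2CCn3c2nsc3=S)c1` differs by a methoxy on an aromatic carbon. In this assay compound 2 likewise gives only a limit, >= 20000 nM. Compound 3 `O=S(=O)(NC1=NCCN1C(=S)SN1CCn2c1nsc2=S)c1ccc(Br)cc1` carries a bromo on an aromatic carbon instead. In this assay compound 3 also gives only a limit, >= 20000 nM.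

None of the steps among these three can be read: a step that the two limits leave unreadable from compound 1 to compound 2, a step that the two limits leave unreadable from compound 1 to compound 3 and a step that the two limits leave unreadable from compound 2 to compound 3. Compound 3 therefore stands where every measured compound of the series stands, namely at the limit of >= 20000 nM in this assay, at which 3 of the 3 values shown sit.

Compound 4 `O=S(=O)(NC1=NCCN1C(=S)SN1CCn2c1nsc2=S)c1ccccc1Cl` is the next member, with 2-chlorophenyl in place of 4-bromophenyl on a sulfonyl sulfur. Within the data shown here, no measured step bears on this change in a readable way, since every aryl variation so far has left the value at the limit. The expectation is therefore that compound 4 also stays at the limit, with an estimated step that the limit leaves unreadable from compound 3 to compound 4. Compound 4 is accordingly estimated at 25000 nM in this assay, within a range from 10000 nM to 60000 nM.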

Compound 4, concentration for 50% growth inhibition: >= 20000 nM
Compound 4 was reported as a limit (the forecaster's own chance of this, stated with the estimate: 85%); the middle value is on the limit's open side.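

In this assay compound 4 gives >= 20000 nM, which is a limit. No step linking compound 4 to compound 1, compound 2 or compound 3 can be read: the limit of >= 20000 nM in this assay, at which 4 of the 4 values shown sit.

The compounds shown leave open whether any aryl group on the sulfonyl sulfur of the shared core gives a numerical value in this assay.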